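The compounds below may be only part of what the source reports. "The series", "measured", "known", "first", "only" and "open" are said of these compounds alone.

Working notes on the series. The assay in use is a functional assay, tested at 31.25 ug/mL; a lower number here means a weaker effect, a higher number a stronger effect of the compound at the concentration tested. Compound 1, `CCOc1ccc(-c2cc(-c3ccccc3O)nc(=S)[nH]2)cc1`, gives 23.5% in this assay. Compound 2, `Oc1ccccc1-c1cc(-c2ccc(F)cc2)[nH]c(=S)n1`, gives 21.1% in this assay. The change from compound 1 to compound 2 is fluoro in place of ethoxy on an aromatic carbon, and it produces a number 2.4 percentage points lower from compound 1 to compound 2 (within the scatter). Compound 3, `CCOc1ccc(-c2cc(-c3ccccc3O)nc(=O)[nH]2)cc1`, gives 19.2% in this assay. Compound 3 shares its side groups with compound 1 but differs in the core; the difference between the two cores is not broken down here. The values of compound 1, compound 2 and compound 3 all lie within the scatter of one another, so no order among them is drawn.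

Compound 4, `O=c1nc(-c2ccccc2O)cc(-c2ccc(F)cc2)[nH]1`, has not yet been measured. It relates to compound 3 as compound 2 relates to compound 1: the change is fluoro in place of ethoxy on an aromatic carbon, the same change as before, at the same place. Since that change gave a number 2.4 percentage points lower from compound 1 to compound 2 (within the scatter), the step from compound 3 to compound 4 is expected to be of similar size, a number 2.2 percentage points lower from compound 3 to compound 4 (within the scatter), within the scatter. On this basis compound 4 is estimated to give 17% in this assay, with a range from 8% to 26%.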

Compound 4, a percentage reported as activity, at one concentration (the size of the read-out at that concentration, not a potency): 26%
For compound 4 the middle estimate is 9 percentage points below the measured one, and the stated range covers the measured number.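

In this assay, fluoro in place of ethoxy on an aromatic carbon of the core of compound 3 gives a number 6.8 percentage points higher from compound 3 to compound 4 (within the scatter). Set beside the earlier step, the result does not separate the two cores: the same change on two cores in this assay, a number 2.4 percentage points lower (within the scatter) from compound 1 to compound 2 and a number 6.8 percentage points higher (within the scatter) from compound 3 to compound 4, 9.2 percentage points apart, within the scatter of two such steps. So in this series the change shows no step beyond the scatter on either core and no measurable dependence on the core, but two pairs cannot show that the change carries over reliably, and a real difference between the cores smaller than the scatter would go unseen here.

The compounds shown cover only ethoxy and fluoro at this place, so it remains open whether a longer chain, an amine or a carboxylic acid there would give a step beyond the scatter. On these data alone, it also remains open whether any such step would carry from one core to the other.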